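Methoxy in place of hydrogen on a phenyl ring

The source may hold more compounds than are shown below. What is called first, only, known or untested is meant among the compounds shown, and "the series" means these compounds.

Of the compounds shown here, two have been measured in an assay for inhibition of protein deacetylase HDAC6 (Homo sapiens); on this read-out higher numbers stand for weaker inhibition and lower numbers for stronger inhibition. Compound 1, with the structure `NS(=O)(=O)NCCCC[C@H](NC(=O)OCc1ccc(Cl)cc1)C(=O)Nc1nc(-c2ccccc2)cs1`, gives 530 nM in this assay. Compound 2, with the structure `NS(=O)(=O)NCCCC[C@H](NC(=O)OCc1ccccc1)c1csc(-c2ccccc2)n1`, gives 400 nM in this assay. The two numbers lie close together, within the usual scatter of repeated measurements, so neither compound can be set apart from the other on these values alone. Compound 2 is the starting point for the next step.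

Compound 3, with the structure `COc1ccc(-c2nc([C@H](CCCCNS(N)(=O)=O)NC(=O)OCc3ccccc3)cs2)cc1`, is not yet measured. It differs from compound 2 in one place: methoxy in place of hydrogen on an aromatic carbon. Put another way, a phenyl ring becomes a 4-methoxyphenyl ring, the new group sitting on an aromatic carbon of a six-membered aromatic ring of carbon only, para to a large group.

Among the compounds with values here, no step between measured compounds is available to guide the size of this change. The expectation is therefore a step of a 1.1-fold lower number from compound 2 to compound 3 (0.02 log units; within the scatter) that stays within the usual scatter, in no clear direction. For compound 3 the estimated value in this assay is 380 nM, with a range from 150 nM to 950 nM.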

Compound 3, half-maximal inhibitory concentration: 480 nM
For compound 3 the middle estimate is 1.3-fold (0.10 log units) below the measured one, and the stated range covers the measured number.
By their numbers in this assay, from the lowest: compounds 2, 3 and 1 (each within the scatter of the next).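

In this assay, putting methoxy on the phenyl ring, para to a large group, gives a 1.2-fold higher number from compound 2 to compound 3 (0.08 log units; within the scatter). Within the data shown here, this is the first single-change comparison, and it shows that phenyl and 4-methoxyphenyl cannot be told apart on this read-out, since the step stays within the scatter of repeated measurements. The added oxygen and carbon therefore leave no detectable mark on the number at this position, although a single pair cannot show how far that holds, and no measurement at hand bears on why the step is so small.

The compounds shown test only one group at this one place, so it remains open whether an amine, a carboxylic acid or a longer chain such as butoxy would also leave the number within the scatter. Also open, from the compounds shown here alone, is whether methoxy would behave the same way on another carbon of the same ring, or on the other six-membered aromatic ring of compound 3.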